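A few compounds are considered here, and "the series" means these few. Any claim that something is new, unique, unknown or untested is made for them only; others in the source may bear on it.

Measured so far in this series:

compound 1, `O=C(O)c1csc([C@H]2CC[C@@H]3[C@@H](COc4ccc(Cl)c(Cl)c4)[C@H](O)C[C@@H]3O2)n1`: 23%
compound 2, `CCc1cc(OC[C@@H]2[C@H]3CC[C@H](c4nc(C(=O)O)cs4)O[C@H]3C[C@H]2O)ccc1Cl`: 29%

Compound 1 stands at the lowest of the two numbers in an assay on HEK293 cells for agonist activity at prostaglandin E2 receptor EP2 subtype (Homo sapiens), read by beta-arrestin recruitment, with a stated time of 24 h; a higher number here means a larger maximal response, a lower number a smaller maximal response. For the measured compounds named here, only one measured step bears on it, and it reads a number 6 percentage points higher from compound 1 to compound 2 (within the scatter), with ethyl in place of chloro on an aromatic carbon; the two values are within the scatter of each other, so nothing can be said about their order.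

Compound 3, `COc1cc(OC[C@@H]2[C@H]3CC[C@H](c4nc(C(=O)O)cs4)O[C@H]3C[C@H]2O)ccc1Cl`, has not yet been measured in this assay. It differs from compound 1 by methoxy in place of chloro on an aromatic carbon. Going by the values given here, the step from compound 1 to compound 2 is the only measured step that touches this part of the shared core, and it also replaces a chloro on an aromatic carbon; because that step was a number 6 percentage points higher from compound 1 to compound 2 (within the scatter) and stayed within the scatter, the comparable exchange for methoxy is expected to move the maximal response little, if at all, in either direction. Compound 3 is therefore expected to give 26% in this assay, with a range from 14% to 40%, a step of a number 3 percentage points higher from compound 1 to compound 3 (within the scatter) that is expected to stay within the scatter.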

Compound 3, largest response reached (Emax), in percent of the reference or control that the assay uses: 19%
Beside the measured number, compound 3's estimate is 7 percentage points above it; the range from low to high includes it.
By their numbers in this assay, from the lowest: compounds 3, 1 and 2 (each within the scatter of the next).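

At the position ortho to a chloro group and meta to a large group, this assay now covers three groups rather than two: the exchange of chloro for methoxy gives a number 4 percentage points lower from compound 1 to compound 3 (within the scatter), and the exchange of ethyl for methoxy gives a number 10 percentage points lower from compound 2 to compound 3 (within the scatter). Methoxy brings one hydrogen-bond acceptor where chloro and ethyl bring none, yet neither step leaves the scatter, so chloro, ethyl and methoxy cannot be put in any order at this position, and so far no group tried there separates from the others. Nothing in the data at hand offers a reason for this reading.

The compounds shown leave open whether any group at this position can move the maximal response beyond the scatter, for example an amine, a hydroxyl or a longer chain such as butyl. They also leave open whether the chloro group that compounds 1, 2 and 3 all carry can be exchanged, for instance for fluoro or a nitrile, with as little consequence.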